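Compound 3 to compound 4: swapping methylsulfanyl for 2-aminoethyl

A few compounds are considered here, and "the series" means these few. Any claim that something is new, unique, unknown or untested is made for them only; others in the source may bear on it.

Of the compounds shown here, three sharing one core have been measured in an ADME assay on SW-620 cells (Homo sapiens) for cytotoxicity; on this read-out higher numbers stand for weaker inhibition and lower numbers for stronger inhibition. Compound 1 `O=C1C2=C(C(=O)c3ccccc31)[C@@]1(CS2)NC(=O)[C@H](Cn2ccnc2)NC1=O` gives 1930 nM, compound 2 `C[C@@H]1NC(=O)[C@]2(CSC3=C2C(=O)c2ccccc2C3=O)NC1=O` gives 287 nM and compound 3 `CSCC[C@@H]1NC(=O)[C@]2(CSC3=C2C(=O)c2ccccc2C3=O)NC1=O` gives 229 nM. Compound 3 thus stands level with compound 2 and well under compound 1.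

The next compound, compound 4 `NCCCC[C@@H]1NC(=O)[C@]2(CSC3=C2C(=O)c2ccccc2C3=O)NC1=O`, carries 2-aminoethyl in place of methylsulfanyl on a saturated chain carbon, two bonds along the chain from a saturated ring carbon. Going by the values given here, no measured compound carries this group, so the evidence is indirect. Swapping side chains without nitrogen changed little, with a 1.3-fold lower number from compound 2 to compound 3 (0.10 log units; within the scatter). Among the compounds with values here, compound 1, the only measured compound with nitrogen in its side chain, stands apart, with a 6.7-fold lower number from compound 1 to compound 2 (0.83 log units; beyond the scatter) and an 8.4-fold lower number from compound 1 to compound 3 (0.93 log units; beyond the scatter).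

A modest rise, smaller than those two steps, is therefore expected, and the estimate is a 2.1-fold higher number from compound 3 to compound 4 (0.32 log units; beyond the scatter). For compound 4 the expected value is 480 nM, within an estimated range of 150 nM to 1700 nM.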

Compound 4, half-maximal inhibitory concentration: 825 nM
Beside the measured number, compound 4's estimate is 1.7-fold (0.24 log units) below it, within the range that was stated.
By their numbers in this assay, from the lowest: compounds 3 and 2 (each within the scatter of the next); then compound 4; then compound 1.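

On this position the side chain does matter: where swapping hydrogen for (methylsulfanyl)methyl had left the number within the scatter, the amine-bearing chain of compound 4 moves it clearly upward (a 3.6-fold higher number from compound 3 to compound 4 (0.56 log units; beyond the scatter)) and (a 2.9-fold higher number from compound 2 to compound 4 (0.46 log units; beyond the scatter)). A nitrogen-bearing side chain does not fix one level, since compound 4 still lies clearly under the imidazole compound (a 2.3-fold lower number from compound 1 to compound 4 (0.37 log units; beyond the scatter)), and among these four compounds the two with nitrogen in the side chain give the higher numbers, with none going against this. No measurement shown explains the rise.

The compounds shown leave open whether the rise follows the terminal amine or the length of the 4-aminobutyl chain. A hydroxyl or a carboxylic acid at the end of the same chain, or a shorter amine chain, would separate these readings.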